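The source may hold more compounds than are shown below. What is called first, only, known or untested is meant among the compounds shown, and "the series" means these compounds.

Measured compounds:
compound 1 `CCCNS(=O)(=O)c1ccc(Nc2ncc3c(n2)N(C2CCCC2)[C@H](CC)C(=O)N3C)cc1`: 2100 nM
compound 2 `CC[C@@H]1C(=O)N(C)c2cnc(-n3ccc4cc(F)ccc43)nc2N1C1CCCC1`: 46500 nM
compound 3 `CCC1C(=O)N(C)c2cnc(-n3ccc4cc(C(=O)NC)ccc43)nc2N1c1ccn(C)n1`: 35700 nM

All three were read in a functional assay on NCI-H1975 cells (Homo sapiens) for antiproliferative activity, read by CCK-8 assay, with a stated time of 72 h; a higher number here means a weaker inhibitor of growth, a lower number a stronger inhibitor of growth. Compound 1 has the lowest of the three numbers. Compound 3 stands nearest to it, with a gap beyond the scatter, and compound 2 stands furthest, also beyond the scatter. Both neighbours differ from compound 1 in more than one place, so neither gap is taken as a single step; only what the two values of each pair show is noted.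

The step under consideration leads to compound 4 `CC[C@@H]1C(=O)N(C)c2cnc(Nc3ccc(S(N)(=O)=O)cc3)nc2N1C1CCCC1`, which has not yet been measured in this assay. Against compound 1 the change is hydrogen in place of propyl on a sulfonamide nitrogen. The propylsulfamoyl group thus becomes a sulfamoyl group, the sulfonamide nitrogen keeping the sulfonyl sulfur as its other neighbour. For the measured compounds named here, no pair of measured compounds shows this change on its own, so there is no measured step to lean on, and the series gives no clue on how such a change has behaved before.

The expected step in this assay is a 1.4-fold higher number from compound 1 to compound 4 (0.15 log units; within the scatter), small, close to the scatter, and if anything towards a higher number. Compound 4 is estimated at 3000 nM, with a range from 1000 nM to 9000 nM.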

Compound 4, concentration for 50% growth inhibition: 5290 nM
Beside the measured number, compound 4's estimate is 1.8-fold (0.25 log units) below it; the measured number falls inside the stated range.
By their numbers in this assay, from the lowest: compound 1; then compound 4; then compounds 3 and 2 (each within the scatter of the next).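

In this assay the sulfonamide nitrogen now has its first measured step, and hydrogen in place of propyl gives a 2.5-fold higher number from compound 1 to compound 4 (0.40 log units; beyond the scatter) as a modest change beyond the scatter. The propylsulfamoyl group is therefore not a requirement for growth inhibition in this series, since compound 4 with its plain sulfamoyl group still reads 5290 nM in the same range of low micromolar numbers, although the propyl chain does carry part of the activity of compound 1. Nothing at hand accounts for the size or direction of this step.

Still open, from the compounds shown here alone, is whether the number follows chain length, with methyl, ethyl or a longer chain on the sulfonamide nitrogen, and whether a chain ending in an amine or a carboxylic acid would behave as propyl does. The step also rests on a single pair, so whether the same change gives a similar step with other groups on the shared core remains to be seen.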